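Shortening the Thiourea Chain on an Iminosugar Galactosidase Inhibitor

The source may report more compounds than this note shows. Statements on the series, on what has been measured and on what is new or still open speak of the compounds shown alone.

Compound 1 `CCCCCCCCCC/N=C1/SC[C@@H]2[C@@H](O)[C@H](O)[C@@H](CO)N12`: 93000 nM in an assay for inhibition of beta-galactosidase (Bos taurus), read by spectrophotometry; a higher number here means a weaker inhibitor, a lower number a stronger inhibitor
Compound 2 `CCCCCCCCCCCCNC(=S)N1[C@H](CO)[C@@H](O)[C@H](O)[C@H]1CO`: 24000 nM

Compound 2 gives the lowest of the two numbers in this assay; compound 1 stands at a higher number, a gap beyond the usual scatter. Compound 3 `CCCCCCCCNC(=S)N1[C@H](CO)[C@@H](O)[C@H](O)[C@H]1CO` differs from compound 2 in one place: hydrogen in place of butyl on a saturated chain carbon, eight bonds along the chain from an amide-type nitrogen. Within the data shown here, no measured pair shows this kind of change, so compound 2 alone anchors the next step. The account expects compound 3 to come out as a somewhat weaker inhibitor, with an estimated step of a 2.5-fold higher number from compound 2 to compound 3 (0.40 log units; beyond the scatter). For compound 3 the estimate in this assay is 60000 nM, with a range from 20000 nM to 250000 nM.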

Compound 3, half-maximal inhibitory concentration: 414000 nM
Compound 3: middle estimate off by 6.9-fold (0.84 log units), on the low side; the whole stated range lies below it.
By their numbers in this assay, from the lowest: compound 2; then compound 1; then compound 3.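

Taking butyl off this saturated chain carbon, eight bonds along the chain from an amide-type nitrogen, gives in this assay a large change of a 17-fold higher number from compound 2 to compound 3 (1.24 log units; beyond the scatter) and so weakens inhibition sharply. This first measured pair of its kind shows that, on the shared core, the outer part of the chain in compound 2 weighs heavily in this assay. Nothing available accounts for the size of the step. Still open, on these data alone, is how the number moves with a longer chain, and whether an amine or a carboxylic acid at this chain carbon would hold the value of compound 2.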